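The compounds below may be only part of what the source reports. "The series", "measured", "known", "first", "only" and "open" are said of these compounds alone.

Compound 3 `CN(Cc1ccc(C2=NCCN2)cc1)C(=O)COCCN(C)S(=O)(=O)c1c(Cl)cccc1Cl` stands lowest of the three measured compounds in an assay on HEK293 cells for displacement of a labelled ligand from B1 bradykinin receptor (Homo sapiens), read by scintillation counting (on this read-out lower numbers stand for stronger inhibition and higher numbers for weaker inhibition), at 4.2 nM. Compound 2 `Cc1c(Cl)cccc1S(=O)(=O)N(C)CCOCC(=O)N(C)Cc1ccc(C2=NCCN2)cc1` gives 6.8 nM, and a 1.6-fold lower number from compound 2 to compound 3 (0.21 log units; within the scatter), so the two cannot be ordered. Compound 1 `CN(Cc1ccc(C2=NCCN2)cc1)C(=O)COCCN(C)S(=O)(=O)c1c(F)cccc1F` gives 142 nM, with a 34-fold lower number from compound 1 to compound 3 (1.53 log units; beyond the scatter) and a 21-fold lower number from compound 1 to compound 2 (1.32 log units; beyond the scatter). Compound 4 `CN(Cc1ccc(C2=NCCN2)cc1)C(=O)COCCN(C)S(=O)(=O)c1ccccc1C(F)(F)F` differs from compound 3 by 2-(trifluoromethyl)phenyl in place of 2,6-dichlorophenyl on a sulfonyl sulfur. All three measured steps change the same aryl group on the sulfonyl sulfur: the two large steps arise from leaving the difluoro pattern, while the swap between the chloro-bearing aryls stays within scatter. Compound 4 keeps a single substituted aryl, so a modest rise in the number is expected, a 2.9-fold higher number from compound 3 to compound 4 (0.46 log units; beyond the scatter). Compound 4 is therefore estimated at 12 nM, within 3 nM to 50 nM.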

Compound 4, inhibition constant: 2.8 nM
Beside the measured number, compound 4's estimate is 4.3-fold (0.63 log units) above it; measured number below the stated range.
By their numbers in this assay, from the lowest: compounds 4, 3 and 2 (each within the scatter of the next, the first and the last beyond it); then compound 1.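

On the sulfonyl sulfur, 2-(trifluoromethyl)phenyl is the first group shown without chlorine that reads alongside 2,6-dichlorophenyl in this assay, with a 1.5-fold lower number from compound 3 to compound 4 (0.18 log units; within the scatter). It also gives a 2.4-fold lower number from compound 2 to compound 4 (0.39 log units; beyond the scatter) and a 51-fold lower number from compound 1 to compound 4 (1.71 log units; beyond the scatter), so fluorine on this aryl group does not in itself go with the high number of compound 1. No evidence given here accounts for these steps. As far as these compounds go, whether a cyclohexyl or pyridyl group on the sulfonyl sulfur would hold such numbers stays open, as does the effect of a methoxy group or nitrile on the phenyl ring.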